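The source may report more compounds than this note shows. Statements on the series, on what has been measured and on what is new or still open speak of the compounds shown alone.

Compound 3 `Cn1nc2c(=O)n(CC3(O)CCN(Cc4ccc(-c5cncs5)cc4Cl)CC3)cnc2c1-c1ccc(CN)cc1` gives the lowest number of the three measured compounds in an assay on isolated protein for inhibition of ubiquitin carboxyl-terminal hydrolase 7 (Homo sapiens), with stated times of 30 min and 2 h (on this read-out higher numbers stand for weaker inhibition and lower numbers for stronger inhibition), at 117 nM. Compound 1 `Cn1nc2c(=O)n(CC3(O)CCN(Cc4ccc(-c5n[nH]c(=O)o5)cc4Cl)CC3)cnc2c1-c1ccc(CN)cc1` gives 171 nM in this assay, and compound 2 `Cn1nc2c(=O)n(CC3(O)CCN(Cc4ccc(-c5ccncc5)cc4Cl)CC3)cnc2c1-c1ccc(CN)cc1` gives 257 nM. The step of a 1.5-fold lower number from compound 1 to compound 3 (0.16 log units; within the scatter) stays within the scatter, while a 2.2-fold lower number from compound 2 to compound 3 (0.34 log units; beyond the scatter) lies beyond it, so swapping the ring on this aromatic carbon has so far shifted the number only modestly. Compound 4 `Cn1nc2c(=O)n(CC3(O)CCN(Cc4ccc(-c5ccsc5)cc4Cl)CC3)cnc2c1-c1ccc(CN)cc1` carries thiophen-3-yl in place of 1,3-thiazol-5-yl on an aromatic carbon. Among the measured compounds shown here, no measured step exchanges one five-membered ring for another that keeps the sulfur but drops the nitrogen, so the only guidance is the mild spread among compounds 1, 2 and 3. The step from compound 3 to compound 4 is therefore expected to be a 1.4-fold higher number from compound 3 to compound 4 (0.14 log units; within the scatter), within the scatter. For compound 4 the estimate is 160 nM, with a range from 70 nM to 380 nM.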

Compound 4, half-maximal inhibitory concentration: 59.5 nM
Estimate against measurement, compound 4: 2.7-fold (0.43 log units) above; the measured number lies below the stated range.
By their numbers in this assay, from the lowest: compounds 4, 3, 1 and 2 (each within the scatter of the next, the first and the last beyond it).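

In this assay, the step of a 2.0-fold lower number from compound 3 to compound 4 (0.29 log units; within the scatter) stays within the scatter, so thiophen-3-yl and 1,3-thiazol-5-yl cannot be told apart on this aromatic carbon, even though one ring nitrogen is gone. Among the compounds shown here, the steps of a 2.9-fold lower number from compound 1 to compound 4 (0.46 log units; beyond the scatter) and a 4.3-fold lower number from compound 2 to compound 4 (0.64 log units; beyond the scatter) both lie beyond the scatter, and the first of these shows for the first time that a ring here can separate clearly from the ring in compound 1. No measurement shown explains these shifts. From the compounds shown here alone, whether a plain phenyl ring or an open-chain amine at this position would give a lower number remains open.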